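Sulfonyl Swap on a Flat Set of Cell Values

The source may hold more compounds than are shown below. What is called first, only, known or untested is meant among the compounds shown, and "the series" means these compounds.

Compound 1 `Cn1c(=O)c(S(=O)(=O)c2ccc(F)cc2F)cc2cnc(Nc3ccc4[nH]c(C(=O)O)cc4c3)nc21`: 10000 nM
Compound 2 `Cn1c(=O)c(S(=O)(=O)c2ccc(C(=O)O)cc2)cc2cnc(Nc3ccc4[nH]ccc4c3)nc21`: 5000 nM
Compound 3 `CN1CCN(c2ccc(Nc3ncc4cc(S(=O)(=O)c5ccc(F)cc5F)c(=O)n(C)c4n3)cc2)CC1`: 5000 nM

All three compounds were tested in a functional assay on K562 cells (Homo sapiens) for inhibition, read by trypan blue exclusion, with a stated time of 72 h; a lower number here means a stronger inhibitor, a higher number a weaker inhibitor. There, compound 2 gives 5000 nM, level with compound 3 at 5000 nM. Compound 1 gives 10000 nM, which stays within the usual scatter of both, so the set shows no real separation.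

The next compound to be tested starts from compound 2. Compound 4 `Cn1c(=O)c(S(=O)(=O)Cc2ccc(F)cc2)cc2cnc(Nc3ccc4[nH]ccc4c3)nc21` carries 4-fluorobenzyl in place of 4-carboxyphenyl on a sulfonyl sulfur. The rest of the structure is unchanged.

For the measured compounds named here, no two measured compounds differ in one place only, so nothing measured sizes this change directly, and the expectation is a loose one. Its starting point is compound 2 at 5000 nM. In this assay a moderate move toward a lower number is expected, though a result level with the starting value would remain possible. The estimated step is a 3.3-fold lower number from compound 2 to compound 4 (0.52 log units; beyond the scatter). For compound 4 the expected value is 1500 nM, with an estimated range of 200 nM to 10000 nM.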

Compound 4, half-maximal inhibitory concentration: 30000 nM
The estimate for compound 4 lay 20-fold (1.30 log units) below the measured number, outside the stated range (above it).
By their numbers in this assay, from the lowest: compounds 2, 3 and 1 (each within the scatter of the next); then compound 4.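

In this assay, for the compounds shown here, the group on the sulfonyl sulfur proves able to move the cell value: the change gives a 6.0-fold higher number from compound 2 to compound 4 (0.78 log units; beyond the scatter), the only step here measured at a single place and one that lies beyond the scatter. Going by these compounds alone, that result goes further than the earlier compounds, whose values showed no real separation and could not size any one change. The swap alters more than one feature at once, since the hydrogen-bond donor and acceptor counted on 4-carboxyphenyl leave while a fluorine enters, and no supporting measurement is available to account for the rise in the number.

The compounds shown do not separate the loss of the carboxylic acid from the entry of 4-fluorobenzyl, a question that an unsubstituted benzyl, a 4-fluorophenyl or a benzyl bearing a carboxylic acid on the sulfonyl sulfur would address more directly. On these data alone, it also remains open whether an amine at this place would give a lower number, and whether the same swap would act alike on the cores of compound 1 and compound 3.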